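Series notes: hexyl chain to bromophenyl on the triazole carbon

The source may report more compounds than this note shows. Statements on the series, on what has been measured and on what is new or still open speak of the compounds shown alone.

Among the measured compounds shown here, compound 3 `CCCCCCc1cn(Cc2cc(=O)oc3cc(O)ccc23)nn1` is the only member of the series with a number in a functional assay on HepG2 cells (Homo sapiens) for inhibition, read by MTT assay, with a stated time of 72 h; on this read-out lower numbers stand for stronger inhibition and higher numbers for weaker inhibition: compound 3 gives 61600 nM. Compound 1 `O=c1cc(Cn2cc(CCCCl)nn2)c2ccc(O)cc2o1` reaches only a limit of the assay, and in this assay compound 1 gives > 100000 nM. Compound 2 `O=c1cc(Cn2cc(CCO)nn2)c2ccc(O)cc2o1` also stops at a limit, and in this assay compound 2 gives > 100000 nM. Both sit at the limit of > 100000 nM in this assay, at which 2 of the 3 values shown sit, so the step that the two limits leave unreadable from compound 1 to compound 2. The steps of an at least 1.6-fold lower number from compound 1 to compound 3 (0.21 log units; that floor lies within the scatter) and an at least 1.6-fold lower number from compound 2 to compound 3 (0.21 log units; that floor lies within the scatter) point towards compound 3, but each carries a floor that lies within the scatter.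

Compound 4 `O=c1cc(Cn2cc(-c3ccc(Br)cc3)nn2)c2ccc(O)cc2o1` differs from compound 3 in 4-bromophenyl in place of hexyl on an aromatic carbon. For the measured compounds named here, both measured steps onto compound 3 altered the end of a saturated chain; no measured step concerns the swap of an alkyl chain for an aromatic ring at this position, so the direction cannot be read from the series. For compound 4 a step within the scatter in this assay is expected, with the limit of the assay within reach. Compound 4 is estimated at 45000 nM, with a range from 12000 nM to 150000 nM. That estimate means an expected step of a 1.4-fold lower number from compound 3 to compound 4 (0.14 log units; within the scatter).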

Compound 4, half-maximal inhibitory concentration: 61100 nM
Compound 4: middle estimate off by 1.4-fold (0.13 log units), on the low side, and the stated range covers the measured number.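

At this aromatic carbon of the five-membered aromatic ring with 3 nitrogen, a ring-bearing group and a saturated chain now read alike in this assay, with the measured step being a 1.0-fold lower number from compound 3 to compound 4 (0.00 log units; within the scatter). Hexyl and 4-bromophenyl are thus not told apart on this read-out, although one six-membered aromatic ring of carbon only enters and a chain with no ring leaves, and compound 3 is no longer the only compound with a number. The other two new steps are an at least 1.6-fold lower number from compound 2 to compound 4 (0.21 log units; that floor lies within the scatter) and an at least 1.6-fold lower number from compound 1 to compound 4 (0.21 log units; that floor lies within the scatter); they give floors only and set no order among these compounds, because each starts from a limit: the limit of > 100000 nM in this assay, at which 2 of the 4 values shown sit.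

Whether any group at this carbon can move the number beyond the scatter stays open, since both numbers shown lie close together and the other two compounds stop at a limit. How an unsubstituted phenyl, an amine or a carboxylic acid would read at this place also remains open, so the compounds shown cannot say whether the bromine in compound 4 matters.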